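The source may report more compounds than this note shows. Statements on the series, on what has been measured and on what is new or still open speak of the compounds shown alone.

Of the compounds shown here, three built on one shared core have been measured in a functional assay on Caco-2 cells (Homo sapiens) for antiproliferative activity, read by MTT assay, with a stated time of 48 h; on this read-out lower numbers stand for stronger inhibition and higher numbers for weaker inhibition. Compound 1 `CCN(CC)CCNC(=O)c1ccc(C(CC)(CC)c2ccc(OCCC(O)(CC)CC)c(C)c2)n1CC` gives 1630 nM in this assay. Compound 2 `C=CCN(C)C(=O)c1ccc(C(CC)(CC)c2ccc(OCCC(O)(CC)CC)c(C)c2)n1CC` reaches only a limit of the assay, recorded as > 50000 nM. Compound 3 `CCC(C)C(NC(=O)c1ccc(C(CC)(CC)c2ccc(OCCC(O)(CC)CC)c(C)c2)n1CC)C(=O)OC` also stops at a limit, recorded as > 50000 nM. For the measured compounds named here, the step of an at least 30-fold higher number from compound 1 to compound 2 (1.48 log units; beyond the scatter) and the step of an at least 30-fold higher number from compound 1 to compound 3 (1.48 log units; beyond the scatter) both run from the one numeric value up to the limit, while the step that the two limits leave unreadable from compound 2 to compound 3 lies between two limits and cannot be sized. Compound 2 therefore stands at the weak end of everything shown, sitting at the limit of > 50000 nM in this assay, at which 2 of the 3 values shown sit.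

Compound 4 `CCn1c(C(=O)N(C)CC(=O)O)ccc1C(CC)(CC)c1ccc(OCCC(O)(CC)CC)c(C)c1` differs from compound 2 by carboxy in place of vinyl on a saturated chain carbon bound to an amide-type nitrogen; read one bond further out, allyl(methyl)carbamoyl becomes (carboxymethyl)(methyl)carbamoyl. Going by the values given here, no measured step alters this part of the molecule, so none bears on the change directly. What the measured steps do show is that both compounds lacking the (2-(diethylamino)ethyl)amino group of compound 1 fall to the limit, and compound 4 keeps the methyl amide of compound 2. The estimate for compound 4 is thus a step of a number no higher from compound 2 to compound 4 (the limit leaves the size open), with no readable movement expected. Compound 4 is expected to give about 50000 nM, within a range from 15000 nM to 200000 nM, most probably reported again only as a limit.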

Compound 4, half-maximal inhibitory concentration: 2740 nM
Compound 4: the middle estimate sits 18-fold (1.26 log units) above what was measured, and the stated range ends above it.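

In this assay, for the compounds shown here, carboxy in place of vinyl on a saturated chain carbon bound to an amide-type nitrogen gives an at least 18-fold lower number from compound 2 to compound 4 (1.26 log units; beyond the scatter), so this position, which no earlier step touched, can carry the whole distance from the limit back to a measurable value. Going by these compounds alone, the loss of the (2-(diethylamino)ethyl)amino group therefore does not by itself end the activity, as the earlier compounds had suggested: with (carboxymethyl)(methyl)amino on the carbonyl carbon instead, the step is a 1.7-fold higher number from compound 1 to compound 4 (0.23 log units; within the scatter), which leaves compound 1 and compound 4 not separable on this read-out. The group on the carbonyl carbon also sets compound 4 apart from the other carboxyl-derived compound, with an at least 18-fold lower number from compound 3 to compound 4 (1.26 log units; beyond the scatter), and nothing measured here accounts for why any of these steps takes the size it does.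

As far as these compounds go, what stays open is whether the carboxylic acid itself carries the gain, or whether a methyl ester or an amine on that same carbon would read alike. Equally open, from the compounds shown here alone, is how a longer chain ending in the carboxylic acid would read in this assay.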